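Moving the amide on the biphenyl terminus of a thromboxane antagonist

A few compounds are considered here, and "the series" means these few. Any claim that something is new, unique, unknown or untested is made for them only; others in the source may bear on it.

Of the compounds shown here, two have been tested in a functional assay for antagonist activity at thromboxane A2 receptor (Rattus norvegicus); a lower number here means tighter binding, a higher number weaker binding. Compound 1, `O=C(O)CC/C=C\CO[C@@H]1[C@@H](OCc2ccc(-c3ccccc3)cc2)CC[C@@H]1N1CCCCC1`, gives 1000 nM in this assay. Compound 2, `NC(=O)c1ccccc1-c1ccc(COC2CC[C@H](N3CCCCCC3)[C@H]2OC/C=C\CCC(=O)O)cc1`, gives 15.9 nM in this assay, the lower of the two numbers; the gap between compound 1 and compound 2 lies well beyond the usual scatter, though the two differ in more than one place, so the two values simply show that compound 2 is the tighter binder of the pair.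

Compound 3, `CC(=O)NCc1ccc(-c2ccc(COC3CC[C@H](N4CCCCCC4)[C@H]3OC/C=C\CCC(=O)O)cc2)cc1`, has not yet been measured in this assay. It differs from compound 2 in one place: 4-(acetamidomethyl)phenyl in place of 2-carbamoylphenyl on an aromatic carbon. The hydrogen-bond donor and acceptor are retained, but they now sit on a longer arm at a different position of the outer ring.

Among the measured compounds shown here, no measured pair in the set shows such a change. The author therefore expects a modest weakening, a step from compound 2 to compound 3 of about a 2.5-fold higher number from compound 2 to compound 3 (0.40 log units; beyond the scatter) in this assay, which may or may not exceed the scatter. On that basis compound 3 is estimated to give 40 nM in this assay, within a range of 10 nM to 160 nM.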

Compound 3, dissociation constant: 20 nM
For compound 3 the middle estimate is 2.0-fold (0.30 log units) above the measured one; low and high end bracket the measured number.
By their numbers in this assay, from the lowest: compounds 2 and 3 (each within the scatter of the next); then compound 1.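

In this assay, 4-(acetamidomethyl)phenyl in place of 2-carbamoylphenyl gives a 1.3-fold higher number from compound 2 to compound 3 (0.10 log units; within the scatter), so this assay does not separate the two compounds. Among the compounds shown here, this is the first comparison that turns on a single place, and it shows that this aromatic carbon, para to a large group, accepts a group of 11 heavy atoms in place of one of 9 with no change beyond the scatter, while both groups keep 1 hydrogen-bond donor and 1 hydrogen-bond acceptor. No accompanying measurement offers an explanation for this agreement.

The result does not show whether the amide carbonyl and its nitrogen are needed at all, and compound 1 cannot answer that, since it differs from compound 2 in more than one place. As far as these compounds go, it also remains open how a carboxylic acid, a primary amine, a nitrile or a longer chain ending in an amide would behave on the outer ring in this assay.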